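Two chains, two side groups: estimating a hybrid analogue

This account rests on a few compounds, and the source may have more. Where it says the series, first, only, none or still open, it means among the compounds named here.

Measured compounds:
Compound 1 `CC(C)=CCC1Cc2c(OCCCOc3ccc(Cl)cc3)cc(=O)n(CCCO)c2CC1(C)C`: 22.7%
Compound 2 `CC(C)=CCC/C(C)=C/CC1Cc2c(OCCCNC(=O)c3cccs3)cc(=O)n(CCCO)c2CC1(C)C`: 72.8%

In a functional assay on PANC-1 cells (Homo sapiens) for inhibition, read by MTT assay, with a stated time of 24 h, tested at 10 uM (on this read-out higher numbers stand for more inhibition at the one concentration tested (going by the name of the read-out) and lower numbers for less inhibition), compound 1 gives 22.7%, while compound 2 gives 72.8%, the higher of the two numbers; the gap between them lies beyond the scatter. Compound 1 and compound 2 differ in more than one place, so their two values show only the combined outcome and no single change can be credited.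

Compound 3 `CC(C)=CCC/C(C)=C/CC1Cc2c(OCCCOc3ccc(Cl)cc3)cc(=O)n(CCCO)c2CC1(C)C` is not yet measured. It keeps the longer side chain of compound 2 and differs from it in one place: 4-chlorophenoxy in place of ((thiophen-2-yl)carbonyl)amino on a saturated chain carbon, three bonds along the chain from an oxygen on an aromatic ring. Among the measured compounds shown here, the entering 4-chlorophenoxy group is the one carried by compound 1, whose value in this assay is low, but compound 1 also lacks the longer chain, so the data give no clean reading of the swap alone. The expected step of a number 27.8 percentage points lower from compound 2 to compound 3 (beyond the scatter) is therefore downward and of moderate size, with wide uncertainty. For compound 3 the estimate is 45%, within a range of 20% to 70%.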

Compound 3, a percentage reported as inhibition, at one concentration (the size of the read-out at that concentration, not a potency): 25.2%
The estimate for compound 3 lay 19.8 percentage points above the measured number; measured number inside the range.
By their numbers in this assay, from the lowest: compounds 1 and 3 (each within the scatter of the next); then compound 2.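

In this assay, 4-chlorophenoxy in place of ((thiophen-2-yl)carbonyl)amino on a saturated chain carbon, three bonds along the chain from an oxygen on an aromatic ring, gives a number 47.6 percentage points lower from compound 2 to compound 3 (beyond the scatter) and so shows, with the longer side chain held constant, that the group at this place matters a great deal. With 4-chlorophenoxy held constant, 3-methylbut-2-en-1-yl in place of hydrogen on a saturated chain carbon bound to a double-bonded chain carbon gives a number 2.5 percentage points higher from compound 1 to compound 3 (within the scatter) and so shows no measurable effect of the longer side chain on this background. No available data bear on the reason for the large step at the chain end.

On these data alone, the longer side chain has been read only with 4-chlorophenoxy on the chain, so its step with ((thiophen-2-yl)carbonyl)amino there remains open. Also open, as far as these compounds go, is which part of ((thiophen-2-yl)carbonyl)amino counts, a question that a benzoylamino group or a plain amine at the same place could help to separate.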